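The source may hold more compounds than are shown below. What is called first, only, known or untested is meant among the compounds shown, and "the series" means these compounds.

Measured in a functional assay on QGY-7703 cells (Homo sapiens) for cytotoxicity, read by MTT assay, with a stated time of 24 h; on this read-out lower numbers stand for stronger inhibition and higher numbers for weaker inhibition:
compound 1 `O=C1/C(=C/c2cccnc2)CN(S(=O)(=O)c2ccc(Cl)cc2)C/C1=C\c1ccccc1C(F)(F)F` gives 3440 nM;
compound 2 `O=C1/C(=C/c2cccnc2)CN(S(=O)(=O)c2ccc(Br)cc2)C/C1=C\c1ccccc1C(F)(F)F` gives 5510 nM;
compound 3 `O=C1/C(=C/c2ccncc2)CN(S(=O)(=O)c2ccc(Cl)cc2)C/C1=C\c1ccccc1C(F)(F)F` gives 12700 nM.

Compound 4 `O=C1/C(=C/c2ccncc2)CN(S(=O)(=O)c2ccc(Br)cc2)C/C1=C\c1ccccc1C(F)(F)F` is not yet measured in this assay. Its core differs from the core of compound 1 by pyridin-4-yl in place of pyridin-3-yl on a double-bonded chain carbon bound to a double-bonded ring carbon, a change that made the step of a 3.7-fold higher number from compound 1 to compound 3 (0.57 log units; beyond the scatter). The change from compound 3 to compound 4 is bromo in place of chloro on an aromatic carbon. The same change occurs once more in the set, as bromo in place of chloro on an aromatic carbon, where it made the step of a 1.6-fold higher number from compound 1 to compound 2 (0.20 log units; within the scatter); the place is the same in both cases, so this is the same change. For the measured compounds named here, the single precedent is the step of a 1.6-fold higher number from compound 1 to compound 2 (0.20 log units; within the scatter), and nothing else in the set bears on it. The step from compound 3 to compound 4 in this assay is therefore expected to be of similar size, a 1.5-fold higher number from compound 3 to compound 4 (0.17 log units; within the scatter). Compound 4 is estimated at 19000 nM, within a range from 10000 nM to 40000 nM.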

Compound 4, half-maximal inhibitory concentration: 7060 nM
The estimate for compound 4 lay 2.7-fold (0.43 log units) above the measured number; the measured number lies below the stated range.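

In this assay the new steps are a 1.8-fold lower number from compound 3 to compound 4 (0.25 log units; within the scatter) and a 1.3-fold higher number from compound 2 to compound 4 (0.11 log units; within the scatter); taken alone, neither separates its two compounds. Across these four compounds, bromo in place of chloro does not carry from one core to the other at a fixed size or direction: the same change on two cores in this assay, a 1.6-fold higher number (0.20 log units; within the scatter) from compound 1 to compound 2 and a 1.8-fold lower number (0.25 log units; within the scatter) from compound 3 to compound 4, 2.9-fold (0.46 log units) apart, beyond the scatter of two such steps. Pyridin-4-yl in place of pyridin-3-yl gives a second gap from the same four compounds, so this is no independent finding and it identifies no cause: the same change on two cores in this assay, a 3.7-fold higher number (0.57 log units; beyond the scatter) from compound 1 to compound 3 and a 1.3-fold higher number (0.11 log units; within the scatter) from compound 2 to compound 4, 2.9-fold (0.46 log units) apart, beyond the scatter of two such steps.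

Still open, on these data alone, is whether either change transfers when fluoro or methoxy stands on the aromatic carbon that carries chloro or bromo. Also open, as far as these compounds go, is how pyridin-2-yl would compare on either core.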